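The source may report more compounds than this note shows. Statements on the series, on what has been measured and on what is new or still open speak of the compounds shown alone.

Measured so far in an assay on isolated protein for inhibition of DNA topoisomerase 1 (Homo sapiens), with a stated time of 30 min, tested at 100 uM; on this read-out higher numbers stand for a stronger effect at the one concentration tested and lower numbers for a weaker effect:
- compound 1, `O=C(CN1CCN(c2cc3c(cc2F)c(=O)c(C(=O)O)cn3C2CC2)CC1)Nc1ccc(C(=O)/C=C/c2ccccc2Cl)cc1`: 70.8%
- compound 2, `COc1ccc(/C=C/C(=O)c2ccc(NC(=O)CN3CCN(c4cc5c(cc4F)c(=O)c(C(=O)O)cn5C4CC4)CC3)cc2)cc1`: 67.6%

Within the data shown here, compound 2 stands lowest of the two numbers, but its only neighbour, compound 1, sits within the scatter of it, so the two read as alike. Among the measured compounds shown here, the one step measured in this assay, a number 3.2 percentage points lower from compound 1 to compound 2 (within the scatter), exchanged the aryl group on the double-bonded chain carbon and moved the number by less than the scatter.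

Compound 3, `COc1ccc(/C=C/C(=O)c2ccc(NC(=O)CN3CCN(c4cc5c(cc4F)c(=O)c(C(=O)O)cn5C4CC4)CC3)cc2)cc1OC`, is not yet measured. It differs from compound 2 by methoxy in place of hydrogen on an aromatic carbon. For the measured compounds named here, no measured step adds a substituent on this aryl ring; the only step that bears on the same region of the molecule is the aryl exchange from compound 1 to compound 2, and that stayed within the scatter. On this basis the expected step of a number 1.6 percentage points lower from compound 2 to compound 3 (within the scatter) is none beyond the scatter. Compound 3 is therefore estimated at 66%, with a range from 50% to 80%.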

Compound 3, a percentage reported as inhibition, at one concentration (the size of the read-out at that concentration, not a potency): 73.2%
Beside the measured number, compound 3's estimate is 7.2 percentage points below it, within the range that was stated.
By their numbers in this assay, from the lowest: compounds 2, 1 and 3 (each within the scatter of the next).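

In this assay, among these compounds, methoxy in place of hydrogen on an aromatic carbon, ortho to a methoxy group and meta to a large group, gives a number 5.6 percentage points higher from compound 2 to compound 3 (within the scatter); this is the only measured change that adds a substituent to this aryl ring rather than exchanging the ring, and its step stays within the scatter. Against 2-chlorophenyl, the 3,4-dimethoxyphenyl group gives a number 2.4 percentage points higher from compound 1 to compound 3 (within the scatter), so the three aryl groups shown read as alike at the one concentration tested. No measurement at hand bears on a cause for these steps.

As far as these compounds go, whether an amine, a carboxylic acid or a longer chain such as ethoxy on this aromatic carbon would give a step beyond the scatter remains open. From the compounds shown here alone, whether compound 1, compound 2 and compound 3 differ in the strength of their effect at the one concentration tested also remains open.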